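Swapping the dithiocarbamate amine of a benzamide series

A few compounds are considered here, and "the series" means these few. Any claim that something is new, unique, unknown or untested is made for them only; others in the source may bear on it.

Measured so far:
- compound 1, `Nc1ccccc1NC(=O)c1ccc(CSC(=S)N2CCCc3ccccc32)cc1`: 38.5%
- compound 2, `Nc1ccccc1NC(=O)c1ccc(CSC(=S)N2CCc3cc(Cl)ccc32)cc1`: 57.7%

In a functional assay on MGC-803 cells (Homo sapiens) for antiproliferative activity, read by CCK-8 assay, with a stated time of 72 h, tested at 2 uM (on this read-out lower numbers stand for a weaker effect and higher numbers for a stronger effect at the one concentration tested), compound 2 gives the higher of the two numbers seen, and compound 1 gives 38.5%. Among the measured compounds shown here, the one measured step is a number 19.2 percentage points higher from compound 1 to compound 2 (beyond the scatter).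

Compound 3, `CC1CCCCN1C(=S)SCc1ccc(C(=O)Nc2ccccc2N)cc1`, is not yet measured. It differs from compound 2 as follows: 2-methylpiperidin-1-yl in place of 5-chloro-2,3-dihydro-1H-indol-1-yl on a thiocarbonyl carbon. For the measured compounds named here, the only known step concerns a different pair of groups on the same thiocarbonyl carbon, so it bears on this change only loosely; it shows that the group on that carbon can shift the read-out by a modest amount. Going by the values given here, with no measured example of the entering group, compound 3 is expected to fall back toward the level of compound 1, an estimated step of a number 22.7 percentage points lower from compound 2 to compound 3 (beyond the scatter). Compound 3 is therefore estimated at 35%, with a range from 15% to 60%.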

Compound 3, a percentage reported as inhibition, at one concentration (the size of the read-out at that concentration, not a potency): 64.4%
For compound 3 the middle estimate is 29.4 percentage points below the measured one, and the stated range ends below it.
By their numbers in this assay, from the lowest: compound 1; then compounds 2 and 3 (each within the scatter of the next).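

In this assay the 2-methylpiperidin-1-yl group on the thiocarbonyl carbon has no aromatic ring and no chlorine, yet the change is a number 6.7 percentage points higher from compound 2 to compound 3 (within the scatter) and so these two compounds count as level. An aromatic ring in this group is therefore not needed to reach this level of inhibition, while replacing 1,2,3,4-tetrahydroquinolin-1-yl with 2-methylpiperidin-1-yl gives a number 25.9 percentage points higher from compound 1 to compound 3 (beyond the scatter) and leaves compound 1 as the one that stands apart. Nothing measured here offers a reason for these results.

As far as these compounds go, it remains open whether the methyl group of compound 3 contributes, which plain piperidin-1-yl would test. From the compounds shown here alone, it also remains open whether another ring, such as morpholin-4-yl, or an open-chain amine, such as diethylamine, would hold the read-out at this level on the thiocarbonyl carbon.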